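A few compounds are considered here, and "the series" means these few. Any claim that something is new, unique, unknown or untested is made for them only; others in the source may bear on it.

Measured compounds:
- compound 1 `CC(C)NC(=O)CC(c1ccc(-c2ccc3cccc(F)c3c2)[nH]c1=O)C(C)C`: < 0.0667 h
- compound 2 `CC(C)C(c1ccc(-c2ccc3cccc(F)c3c2)[nH]c1=O)N1CCCCC1=O`: 0.102 h
- compound 3 `CC(C)[C@H](C[C@H]1CCNC1=O)c1ccc(-c2ccc3cccc(F)c3c2)[nH]c1=O`: 0.227 h

The read-out here is an ADME assay on microsomes from liver (Rattus norvegicus) for metabolic stability; on this read-out higher numbers stand for a longer-lived compound and lower numbers for a shorter-lived compound. Compound 1 gives only a limit in this assay, not a number, which is the limit of < 0.0667 h in this assay, at which 1 of the 3 values shown sits. Compound 2 and compound 3 both give numbers. Among the compounds with values here, the one step among the measured compounds that changes a single place is an at least 1.5-fold higher number from compound 1 to compound 2 (0.18 log units; that floor lies within the scatter), where a ring-closed lactam replaces the open amide chain on the saturated chain carbon.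

Compound 4 `CC(C)C(/C=C1\CCNC1=O)c1ccc(-c2ccc3cccc(F)c3c2)[nH]c1=O` differs from compound 1 by a group of 7 heavy atoms (5 carbon, 1 nitrogen, 1 oxygen; one five-membered non-aromatic ring with 1 hetero atom) in place of a group of 7 heavy atoms (5 carbon, 1 nitrogen, 1 oxygen; no ring), on a saturated chain carbon bound to an aromatic carbon and a saturated chain carbon. This change bears a family resemblance to the step from compound 1 to compound 2: in both, the open (isopropylcarbamoyl)methyl gives way to a lactam ring held close to the chain carbon. Within the data shown here, compound 3, which carries a five-membered lactam on that same chain carbon through a saturated link, gives 0.227 h in this assay; no single-place step ties it to compound 1 or compound 4, so only that number is known for it.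

On this basis compound 4 is expected to come out at 0.15 h, estimated between 0.05 h and 0.45 h. That corresponds to an expected step of an at least 2.2-fold higher number from compound 1 to compound 4 (0.35 log units; beyond the scatter).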

Compound 4, half-life: 0.345 h
The estimate for compound 4 lay 2.3-fold (0.36 log units) below the measured number, and the stated range covers the measured number.
By their numbers in this assay, from the lowest: compound 2; then compounds 3 and 4 (each within the scatter of the next). At a limit, below all of these: compound 1.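

In this assay, replacing the open (isopropylcarbamoyl)methyl on the saturated chain carbon bound to an aromatic carbon and a saturated chain carbon with the five-membered ring group of compound 4 gives an at least 5.1-fold higher number from compound 1 to compound 4 (0.71 log units; beyond the scatter), so a ring at this place now gives a step that clears the scatter, which the floor of the step to the six-membered ring of compound 2 did not do. The two ring groups are not interchangeable here: with the same count of heavy atoms, the change gives a 3.4-fold higher number from compound 2 to compound 4 (0.53 log units; beyond the scatter). Compound 1 gives only a limit, so the first of these steps is a floor and not a full size: the limit of < 0.0667 h in this assay, at which 1 of the 4 values shown sits.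

Compound 3 at 0.227 h and compound 4 at 0.345 h lie within the scatter of each other, which leaves open whether the extra double bond of compound 4 counts for anything in this read-out. Also open, from the compounds shown here alone, is how the same chain carbon would respond to a group of another kind, such as a carboxylic acid, an amine or a longer chain ending in a lactam.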